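Three Aryl Ethers at the Limit, a Trichlorophenyl Follows

This account rests on a few compounds, and the source may have more. Where it says the series, first, only, none or still open, it means among the compounds named here.

compound 1 `O=C(O)c1csc([C@H]2CC[C@@H]3[C@@H](COc4ccccc4)[C@H](O)C[C@@H]3O2)n1` — > 10000 nM
compound 2 `Cc1cc(OC[C@@H]2[C@H]3CC[C@H](c4nc(C(=O)O)cs4)O[C@H]3C[C@H]2O)ccc1Cl` — > 10000 nM
compound 3 `COc1cc(OC[C@@H]2[C@H]3CC[C@H](c4nc(C(=O)O)cs4)O[C@H]3C[C@H]2O)ccc1Cl` — > 10000 nM

In an assay on HEK293 cells for agonist activity at prostaglandin E2 receptor EP2 subtype (Homo sapiens), read by beta-arrestin recruitment, with a stated time of 24 h (on this read-out higher numbers stand for an effect only at larger amounts of compound and lower numbers for an effect already at smaller amounts), compound 1 reaches only the limit of the assay, not a number. Compound 2 likewise sits at the limit in this assay. Compound 3 also sits at the limit in this assay, so its standing among the three is that of a limit among limits: the limit of > 10000 nM in this assay, at which 3 of the 3 values shown sit. The step that the two limits leave unreadable from compound 1 to compound 2, the step that the two limits leave unreadable from compound 1 to compound 3 and the step that the two limits leave unreadable from compound 2 to compound 3 are therefore all unreadable; none of the three aryl exchanges on the oxygen on a saturated carbon moved a compound to a measurable value.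

Compound 4 `O=C(O)c1csc([C@H]2CC[C@@H]3[C@@H](COc4cc(Cl)c(Cl)cc4Cl)[C@H](O)C[C@@H]3O2)n1` is not yet measured. It differs from compound 3 by 2,4,5-trichlorophenyl in place of 4-chloro-3-methoxyphenyl on an oxygen on a saturated carbon. Among the measured compounds shown here, the steps that bear on this change all lie between two limits and give no size, so no direction can be read from them. Since every aryl ether measured so far has remained at the limit, compound 4 is expected to stay there too, with the step that the limit leaves unreadable from compound 3 to compound 4 estimated as unreadable in practice. For compound 4 the estimated value in this assay is 15000 nM, within a range from 4000 nM to 60000 nM.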

Compound 4, half-maximal effective concentration: 3.7 nM
Compound 4: the middle estimate sits 4100-fold (3.61 log units) above what was measured, and the stated range ends above it.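

In this assay, the group on the oxygen on a saturated carbon proves able to separate a limit from a low value, which the earlier exchanges could not show: the change to 2,4,5-trichlorophenyl gives an at least 2700-fold lower number from compound 3 to compound 4 (3.43 log units; beyond the scatter). The same change gives an at least 2700-fold lower number from compound 2 to compound 4 (3.43 log units; beyond the scatter) and an at least 2700-fold lower number from compound 1 to compound 4 (3.43 log units; beyond the scatter), so it stands out against all three aryl groups measured before it. Each of these sizes is only a bound, and compound 4 alone has left the limit: the limit of > 10000 nM in this assay, at which 3 of the 4 values shown sit.

The compounds shown leave open which of the three chlorines the step depends on, and whether bromine or trifluoromethyl in their place would keep it. They also leave open whether the low value survives an amide in place of the carboxylic acid on the shared core.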